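Agonist efficacy of biaryl imidazolines at the alpha-2C receptor

The compounds below may be only part of what the source reports. "The series", "measured", "known", "first", "only" and "open" are said of these compounds alone.

Compounds measured so far:
compound 1, `Cc1ccc(-c2ccccc2OC(C)C2=NCCN2)cc1`, 0.46
compound 2, `Cc1ccccc1-c1ccccc1OC(C)C1=NCCN1`, 0.45
compound 3, `CC(Oc1ccccc1-c1cccs1)C1=NCCN1`, 0.8

In a functional assay on CHO cells for agonist activity at Alpha-2C adrenergic receptor (Homo sapiens) (a higher number here means a larger maximal response, a lower number a smaller maximal response), compound 3 stands highest of the three, with 0.8. The two methylphenyl compounds lie close together: the change a number 0.010 lower from compound 1 to compound 2 (within the scatter) is within the scatter. By contrast the steps a number 0.34 higher from compound 1 to compound 3 (beyond the scatter) and a number 0.35 higher from compound 2 to compound 3 (beyond the scatter) are both large, so exchanging a methylphenyl for a thiophen-2-yl on that aromatic carbon raised the maximal response markedly.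

Compound 4, `CC(Oc1ccccc1-c1ccccn1)C1=NCCN1`, is not yet measured. Its change from compound 3 is pyridin-2-yl in place of thiophen-2-yl on an aromatic carbon. Going by the values given here, no measured step covers an exchange between two heteroaryl groups of this kind; the only bearing steps show that the thiophen-2-yl compound stood well above the methylphenyl pair. On that basis compound 4 is expected to sit between the two measured levels, somewhat below compound 3, with a number 0.15 lower from compound 3 to compound 4 (beyond the scatter) as the estimated step. Compound 4 is therefore estimated at 0.65, within a range from 0.4 to 0.9.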

Compound 4, intrinsic activity: the largest response reached, as a fraction of the reference agonist's: < 0.3
Compound 4: no number, only a limit; the forecaster's own chance of this, stated with the estimate: 0%; middle value at least 0.35 from the limit.
By their numbers in this assay, from the lowest: compounds 2 and 1 (each within the scatter of the next); then compound 3. At a limit, below all of these: compound 4.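

The exchange of thiophen-2-yl for pyridin-2-yl gives a number at least 0.50 lower from compound 3 to compound 4 (beyond the scatter) in this assay, so at this aromatic carbon the maximal response depends strongly on which aromatic ring with one hetero atom is present. Going by these compounds alone, the pyridin-2-yl compound also falls under both methylphenyl compounds, with a number at least 0.15 lower from compound 2 to compound 4 (beyond the scatter) and a number at least 0.16 lower from compound 1 to compound 4 (beyond the scatter), so a hetero atom in this ring does not by itself raise the response, and the position can carry the response lower than the earlier compounds showed. Compound 4 has only a limit and not a number, so these steps are minimum sizes: the limit of < 0.3 in this assay, at which 1 of the 4 values shown sits.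

As far as these compounds go, how far compound 4 lies under that limit remains open. Also open, from the compounds shown here alone, is whether the fall goes with the six-membered ring or with its nitrogen, a question on which a furan-2-yl or an unsubstituted phenyl group on the same carbon would bear.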